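This account rests on a few compounds, and the source may have more. Where it says the series, first, only, none or still open, it means among the compounds named here.

Compounds measured so far:
- compound 1, `COc1ccc(C(=O)/C=C/c2nc3ccccc3cc2-c2ccc(OC)cc2)cc1`, gives 8500 nM in a functional assay on A549 cells (Homo sapiens) for antiproliferative activity, read by XTT assay, with a stated time of 72 h; on this read-out higher numbers stand for weaker inhibition and lower numbers for stronger inhibition
- compound 2, `COc1ccc(-c2cc3ccccc3nc2/C=C/C(=O)c2ccc(OC)cc2OC)cc1`, gives 7990 nM in this assay
- compound 3, `COc1ccc(-c2cc3ccccc3nc2/C=C/C(=O)c2ccc(N)cc2)cc1`, gives 7530 nM in this assay

Compound 3 holds the lowest number of the three, yet all three sit within the usual scatter of one another, so no ranking can be read from them. Compound 4, `COc1ccc(-c2cc3ccccc3nc2/C=C/C(=O)c2ccccn2)cc1`, differs from compound 3 by pyridin-2-yl in place of 4-aminophenyl on a carbonyl carbon. The earlier changes on this part of the molecule, a 1.1-fold lower number from compound 2 to compound 3 (0.03 log units; within the scatter) and a 1.1-fold lower number from compound 1 to compound 2 (0.03 log units; within the scatter), were both within the scatter, and the third, a 1.1-fold lower number from compound 1 to compound 3 (0.05 log units; within the scatter), was as well. On that basis no step beyond the scatter is expected, and the estimate for compound 4 in this assay is 7500 nM, ranging from 3000 nM to 20000 nM, which corresponds to an expected step of a 1.0-fold lower number from compound 3 to compound 4 (0.00 log units; within the scatter).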

Compound 4, half-maximal inhibitory concentration: 6140 nM
For compound 4 the middle estimate is 1.2-fold (0.09 log units) above the measured one; measured number inside the range.
By their numbers in this assay, from the lowest: compounds 4, 3, 2 and 1 (each within the scatter of the next).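

Pyridin-2-yl brings a hetero atom into the ring on the carbonyl carbon, where the earlier compounds carried only carbon rings. In this assay this change still leaves every step small: a 1.2-fold lower number from compound 3 to compound 4 (0.09 log units; within the scatter) and a 1.3-fold lower number from compound 2 to compound 4 (0.11 log units; within the scatter) and a 1.4-fold lower number from compound 1 to compound 4 (0.14 log units; within the scatter) show no separation among the four groups at this position. Nothing available accounts for this flat result.

Still open, as far as these compounds go, is whether a group without an aromatic ring on the carbonyl carbon, such as methyl or piperidine, would give a step beyond the scatter. Pyridin-3-yl and pyridin-4-yl also remain open, so the effect of the ring nitrogen's placement cannot be judged.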